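Compound 3 in the antiproliferation series: expected read-out

The source may report more compounds than this note shows. Statements on the series, on what has been measured and on what is new or still open speak of the compounds shown alone.

Working notes on a small set sharing one core. Compound 1 `Cc1nn(-c2nc(-c3ccc(Cl)c(Cl)c3)c(SC(C)C)s2)c(C(=O)O)c1-c1cnccn1` gives 14000 nM in a functional assay on BJAB cells (Homo sapiens) for antiproliferative activity, with a stated time of 4 days; on this read-out higher numbers stand for an effect only at larger amounts of compound and lower numbers for an effect already at smaller amounts. Compound 2 `Cc1nn(-c2nc(-c3ccc(Cl)c(Cl)c3)c(SC(C)C)s2)c(C(=O)O)c1-c1ccc(C(F)(F)F)cc1` gives 3500 nM. Within the data shown here, the single measured step, a 4.0-fold lower number from compound 1 to compound 2 (0.60 log units; beyond the scatter), is the only comparison available, and on it compound 2 stands with the lowest number of the two, the nearest being compound 1 at a higher number beyond the scatter.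

Compound 3 `Cc1nn(-c2nc(-c3ccc(Cl)c(Cl)c3)c(SC(C)C)s2)c(C(=O)O)c1Cc1ccccc1[N+](=O)[O-]` is the next member. Its change from compound 2 is 2-nitrobenzyl in place of 4-(trifluoromethyl)phenyl on an aromatic carbon. Among the measured compounds shown here, no measured step exchanges an aryl group for a benzyl group at this position, so the measured step bears on it only in showing that this position tolerates different groups with a change of modest size. For the step from compound 2 to compound 3 a step of similar or smaller size is expected, most likely toward a higher number, as a 1.7-fold higher number from compound 2 to compound 3 (0.23 log units; within the scatter). Compound 3 is therefore estimated at 6000 nM in this assay, with a range from 1500 nM to 25000 nM.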

Compound 3, half-maximal effective concentration: 20000 nM
For compound 3 the middle estimate is 3.3-fold (0.52 log units) below the measured one; the range from low to high includes it.
By their numbers in this assay, from the lowest: compound 2; then compounds 1 and 3 (each within the scatter of the next).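

In this assay, the exchange of an aryl group for a benzyl group at this position, on the aromatic carbon next to the ring atom that bears a carboxy group, gives a 5.7-fold higher number from compound 2 to compound 3 (0.76 log units; beyond the scatter), although the entering and leaving groups have the same heavy-atom count and each holds one six-membered aromatic ring of carbon only. Against pyrazin-2-yl, the 2-nitrobenzyl group gives a 1.4-fold higher number from compound 1 to compound 3 (0.15 log units; within the scatter), so among these three compounds only the 4-(trifluoromethyl)phenyl group of compound 2 stands apart beyond the scatter, from both compound 1 and compound 3. No supporting measurement on hand accounts for this step or for the closeness of compound 1 and compound 3.

The step from compound 2 to compound 3 changes both the link to the ring and the substituent on it, so the compounds shown leave open how much of it follows the added carbon link and how much the exchange of trifluoromethyl for nitro. A plain benzyl or a 4-(trifluoromethyl)benzyl group at this position would separate the two, and an amine in place of the nitro group would test the substituent alone.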